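The source may hold more compounds than are shown below. What is called first, only, known or untested is meant among the compounds shown, and "the series" means these compounds.

Three ureas on a shared core have been run in a functional assay on PC-3 cells (Homo sapiens) for antiproliferative activity, read by MTT assay, with a stated time of 48 h; a higher number here means a weaker inhibitor, a lower number a stronger inhibitor. Compound 1 `Cc1cccc(NC(=O)Nc2nnc(Sc3ncnc4scc(-c5ccncc5)c34)s2)c1` gives 5200 nM. Compound 2 `O=C(Nc1cccc(Cl)c1)Nc1nnc(Sc2ncnc3scc(-c4ccncc4)c23)s1` gives 8000 nM. The difference between them is chloro in place of methyl on an aromatic carbon, and the step is a 1.5-fold higher number from compound 1 to compound 2 (0.19 log units; within the scatter). Compound 3 `Cc1ccc(NC(=O)Nc2nnc(Sc3ncnc4scc(-c5ccncc5)c34)s2)cc1Cl` gives 4700 nM, the lowest of the three numbers; its nearest neighbour is compound 1, with a 1.1-fold lower number from compound 1 to compound 3 (0.04 log units; within the scatter), and its furthest is compound 2, with a 1.7-fold lower number from compound 2 to compound 3 (0.23 log units; within the scatter). All three therefore sit within the scatter of one another and no order among them can be claimed.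

Compound 4 `Cc1ccc(NC(=O)Nc2nnc(Sc3ncnc4scc(-c5ccncc5)c34)s2)cc1` has not yet been measured. It differs from compound 3 by hydrogen in place of chloro on an aromatic carbon. Among the compounds with values here, two measured steps touch this part of the ring: a 1.5-fold higher number from compound 1 to compound 2 (0.19 log units; within the scatter) exchanged methyl for chloro there, and a 1.7-fold lower number from compound 2 to compound 3 (0.23 log units; within the scatter) put methyl in place of hydrogen on an aromatic carbon. Neither moved the number in this assay beyond the scatter, and nothing among these three compounds shows that the chloro is doing work. No step beyond the scatter is expected in this assay. The step from compound 3 to compound 4 is estimated at a 1.2-fold higher number from compound 3 to compound 4 (0.07 log units; within the scatter). Compound 4 is expected to give 5500 nM, with a range from 2500 nM to 12000 nM.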

Compound 4, half-maximal inhibitory concentration: 2100 nM
Estimate against measurement, compound 4: 2.6-fold (0.42 log units) above; the whole stated range lies above it.
By their numbers in this assay, from the lowest: compound 4; then compounds 3, 1 and 2 (each within the scatter of the next).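

Taking the chloro out of the 3-chloro-4-methylphenyl group gives a step beyond the scatter in this assay (a 2.2-fold lower number from compound 3 to compound 4 (0.35 log units; beyond the scatter)), so this place on the ring, ortho to a methyl group, is not silent, and hydrogen there gives the lower number. The 4-methylphenyl urea also separates from both other ureas with a single ring substituent, by a modest step from the 3-methylphenyl urea (a 2.5-fold lower number from compound 1 to compound 4 (0.39 log units; beyond the scatter)) and a modest step from the 3-chlorophenyl urea (a 3.8-fold lower number from compound 2 to compound 4 (0.58 log units; beyond the scatter)), although compound 1 and compound 2 stay within the scatter of each other, so the gain is tied to this one substitution pattern among the compounds shown. Nothing at hand accounts for these steps.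

Within the data shown here, whether hydrogen is the preferred group at this place stays open, since chloro is its only comparison there, and a fluoro, a methoxy or an amine at the same carbon would show whether the step follows the chloro alone or any group other than hydrogen. Also open, going by these compounds, is what the 4-methyl itself contributes, which an unsubstituted phenyl or a 4-ethylphenyl on the urea would test against compound 4.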